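Taking the benzyl group off compound 2

A few compounds are considered here, and "the series" means these few. Any claim that something is new, unique, unknown or untested is made for them only; others in the source may bear on it.

Compound 1 `CC(=O)Nc1c(C)c(C(OC(C)(C)C)C(=O)O)c(-c2ccc(C)c(C)c2)c(C)c1-c1ccc(C)c(C)c1` gives 19000 nM
Compound 2 `Cc1ccc(-c2c(C)c(-c3ccc(C)c(C)c3)c(C(OC(C)(C)C)C(=O)O)c(C)c2NCc2ccccc2)cc1C` gives 4000 nM

In an ADME assay on MT4 cells (Homo sapiens) for cytotoxicity, read by MTT assay, with a stated time of 4 days (a higher number here means that more compound is tolerated, a lower number that less compound is tolerated), compound 2 holds the lower of the two numbers, so less of it is tolerated than of compound 1. The change hydrogen in place of benzyl on a nitrogen on an aromatic ring turns benzylamino to amino and leads to compound 3 `Cc1ccc(-c2c(C)c(-c3ccc(C)c(C)c3)c(C(OC(C)(C)C)C(=O)O)c(C)c2N)cc1C` with hydrogen in place of benzyl on a nitrogen on an aromatic ring. Among the compounds with values here, only one measured step bears on this nitrogen: a 4.8-fold lower number from compound 1 to compound 2 (0.68 log units; beyond the scatter) with benzyl in place of acetyl. Compound 3 carries neither group, so that step is only an indirect guide. With the benzyl gone, the number is expected to move back up, and the expected size is a 2.8-fold higher number from compound 2 to compound 3 (0.44 log units; beyond the scatter) in this assay as a rough guess. For compound 3 the estimated value is 11000 nM with an expected range from 4500 nM to 25000 nM in this measurement.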

Compound 3, half-maximal cytotoxic concentration: 12000 nM
Estimate against measurement, compound 3: 1.1-fold (0.04 log units) below; measured number inside the range.
By their numbers in this assay, from the lowest: compound 2; then compounds 3 and 1 (each within the scatter of the next).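

Across the three groups seen on this nitrogen in this assay, only benzyl stands apart: replacing it with hydrogen gives a 3.0-fold higher number from compound 2 to compound 3 (0.48 log units; beyond the scatter). The amino and acetamide forms cannot be separated, since replacing acetyl with hydrogen gives a 1.6-fold lower number from compound 1 to compound 3 (0.20 log units; within the scatter), so the lower number belongs to the benzyl compound alone rather than to any change away from the free amino group. No measurement shown offers a reason for this difference.

On these data alone, what stays open is whether the aromatic ring of the benzyl group matters or whether any carbon group on this nitrogen would do the same. A methyl group, a longer alkyl chain or a cyclohexylmethyl group on the nitrogen would separate those two readings.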